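This account rests on a few compounds, and the source may have more. Where it says the series, first, only, none or still open, it means among the compounds named here.

In a functional assay on A549 cells (Homo sapiens) for antiproliferative activity, read by MTT assay, with a stated time of 48 h (a lower number here means a stronger inhibitor, a higher number a weaker inhibitor), compound 1 `COc1ccc(-c2nc3cccc(-c4cc(OC)c(OC)c(OC)c4)c3o2)cc1` gives 2200 nM, compound 2 `COc1cccc(-c2nc3cccc(-c4cc(OC)c(OC)c(OC)c4)c3o2)c1` gives 3500 nM, and compound 3 `COc1cc(-c2cccc3nc(-c4ccc(Cl)cc4)oc23)cc(OC)c1OC` gives 5600 nM. Compound 3 therefore stands clearly apart only from compound 1, while the other two steps, a 1.6-fold higher number from compound 2 to compound 3 (0.20 log units; within the scatter) and a 1.6-fold higher number from compound 1 to compound 2 (0.20 log units; within the scatter), stay small. Compound 4 `COc1cc(-c2cccc3nc(-c4ccc(N)cc4)oc23)cc(OC)c1OC` carries one change, amino in place of chloro on an aromatic carbon. Among the measured compounds shown here, no amino compound has been measured yet, so the closest guide is the methoxy-to-chloro step, a 2.5-fold higher number from compound 1 to compound 3 (0.41 log units; beyond the scatter). Reversing that direction, a modest move toward a lower number is expected in this assay, though with little certainty. The expected step is a 2.8-fold lower number from compound 3 to compound 4 (0.45 log units; beyond the scatter). For compound 4 the estimate is 2000 nM, with an expected range from 600 nM to 6000 nM.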

Compound 4, half-maximal inhibitory concentration: 720 nM
For compound 4 the middle estimate is 2.8-fold (0.44 log units) above the measured one; low and high end bracket the measured number.
By their numbers in this assay, from the lowest: compound 4; then compounds 1, 2 and 3 (each within the scatter of the next, the first and the last beyond it).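

In this assay, the group para to a large group proves able to lower the number well beyond the scatter: amino in place of chloro gives a 7.8-fold lower number from compound 3 to compound 4 (0.89 log units; beyond the scatter) on this ring. The amino compound also outperforms both methoxy compounds, with a 3.1-fold lower number from compound 1 to compound 4 (0.49 log units; beyond the scatter) and a 4.9-fold lower number from compound 2 to compound 4 (0.69 log units; beyond the scatter) as the steps, which makes compound 4 the most potent of the four. Nothing measured here explains this gain. As far as these compounds go, whether a dimethylamino group or a hydroxyl group at the same place would match amino remains open.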